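Shrinking the Alkyne Terminus from Cyclohexenyl to Cyclopropyl

The compounds below may be only part of what the source reports. "The series", "measured", "known", "first", "only" and "open" are said of these compounds alone.

Two compounds have been measured in a functional assay on 1321-N1 cells for agonist activity at Free fatty acid receptor 1 (Homo sapiens), read by calcium flux, with a stated time of 0.4 s; a lower number here means that less compound is needed, a higher number that more compound is needed for the effect:
Compound 1, `CC(C)=C(C)C#Cc1ccc(CCC(=O)O)cc1`, gives 83.2 nM.
Compound 2, `O=C(O)CCc1ccc(C#CC2=CCCCC2)cc1`, gives 200 nM.

Compound 2 stands as the higher of the two numbers, separated from compound 1 by the step of a 2.4-fold higher number from compound 1 to compound 2 (0.38 log units; beyond the scatter). Compound 3, `O=C(O)CCc1ccc(C#CC2CC2)cc1`, carries cyclopropyl in place of cyclohex-1-en-1-yl on a triple-bonded carbon. Among the compounds with values here, no measured pair exchanges a ring for a cyclopropyl, so the only guide is the single change seen at this position, a 2.4-fold higher number from compound 1 to compound 2 (0.38 log units; beyond the scatter), which already moved the number beyond the scatter when one unsaturated group was traded for another of similar size. The present change is larger in kind, leaving a far smaller ring without the double bond, so a step of at least the same order, toward a higher number, is expected in this assay. Compound 3 is therefore estimated at 600 nM, within 200 nM to 1800 nM. The expected step is a 3.0-fold higher number from compound 2 to compound 3 (0.48 log units; beyond the scatter).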

Compound 3, half-maximal effective concentration: 5010 nM
For compound 3 the middle estimate is 8.4-fold (0.92 log units) below the measured one; measured number above the stated range.
By their numbers in this assay, from the lowest: compound 1; then compound 2; then compound 3.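

Within the data shown here, at this triple-bonded carbon, this assay responds far more strongly than the single earlier exchange indicated: cyclopropyl in place of cyclohex-1-en-1-yl gives a 25-fold higher number from compound 2 to compound 3 (1.40 log units; beyond the scatter) as a large step, whereas the exchange between the two unsaturated groups was modest. Set against the 1,2-dimethylprop-1-en-1-yl group, cyclopropyl gives a 60-fold higher number from compound 1 to compound 3 (1.78 log units; beyond the scatter) and leaves compound 3 with the highest number of the three, so neither of the larger unsaturated groups is matched by this small ring. Nothing available explains the size of these steps.

Cyclopropyl differs from cyclohex-1-en-1-yl both in its heavy atoms and in lacking the double bond, and the compounds shown do not separate these two differences. As far as these compounds go, whether a cyclohexyl or a cyclopentyl group on the triple-bonded carbon would give a number nearer that of compound 2 or that of compound 3 remains open.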